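This account rests on a few compounds, and the source may have more. Where it says the series, first, only, none or still open, it means among the compounds named here.

Series notes. Compound 1 `CNc1nc(N)n2nc(-c3ccco3)nc2n1` in an assay on CHO cells for displacement of a labelled ligand from adenosine receptor A1 (Homo sapiens) (a lower number here means a stronger inhibitor, a higher number a weaker inhibitor), gives 2570 nM, the second highest of three numbers. Compound 2 `CC(C)Nc1nc(N)n2nc(-c3ccco3)nc2n1` gives 4310 nM; a 1.7-fold higher number from compound 1 to compound 2 (0.22 log units; within the scatter). Compound 3 `c1coc(-c2nc3nc(NC4CCCCC4)nc(NC4CCCCC4)n3n2)c1`, carrying two cyclohexyl groups on its two amine nitrogens, gives 306 nM, the lowest number of the three. Compound 4 `CNc1nc(NCc2ccc(F)cc2)n2nc(-c3ccco3)nc2n1` is not yet measured. It differs from compound 1 by 4-fluorobenzyl in place of hydrogen on a nitrogen on an aromatic ring. Among the measured compounds shown here, the only measured step, a small alkyl change on the other nitrogen, stayed within the scatter, and no step on this nitrogen is available; compound 3 shows only that larger substituents on both nitrogens go with a lower number. A step of a 2.9-fold lower number from compound 1 to compound 4 (0.46 log units; beyond the scatter) toward a lower number is expected, though uncertain in size. Compound 4 is estimated at 900 nM, within 200 nM to 4000 nM.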

Compound 4, inhibition constant: 3080 nM
Compound 4: the middle estimate sits 3.4-fold (0.53 log units) below what was measured; the range from low to high includes it.
By their numbers in this assay, from the lowest: compound 3; then compounds 1, 4 and 2 (each within the scatter of the next).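

On this nitrogen, 4-fluorobenzyl in place of hydrogen gives a 1.2-fold higher number from compound 1 to compound 4 (0.08 log units; within the scatter) in this assay, so this position carries a substituent of this size with no change beyond the scatter. This single step gives no support, on this nitrogen, for a link between a larger substituent and a lower number. Nothing available explains the size of this step.

From the compounds shown here alone, whether a plain benzyl or a longer chain ending in an amine on this nitrogen would move the number remains open. Also open, going by these compounds, is which of the two cyclohexyl groups of compound 3 goes with its lower number.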